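The source may report more compounds than this note shows. Statements on the series, on what has been measured and on what is new or still open speak of the compounds shown alone.

Measured to date:
compound 1, `Nc1ccc2cccc(OCCC3CCCCC3)c2n1`: 808 nM
compound 2, `CC1CC1COc1cccc2ccc(N)nc12`: 1640 nM
compound 3, `Nc1ccc2cccc(OCC3CC4CCC3C4)c2n1`: 137 nM

All three were run in an assay on cells with melanin-concentrating hormone receptor 1 (Homo sapiens) as the target, read by radioligand binding; a lower number here means a stronger inhibitor, a higher number a weaker inhibitor. Among these numbers compound 2 stands highest: compound 1 lies nearest to it, yet beyond the scatter, and compound 3 lies furthest, well beyond the scatter.

Compound 4, `CC(C)=CCOc1cccc2ccc(N)nc12`, has not been measured in this assay. It differs from compound 2 in one place: 2-methylprop-1-en-1-yl in place of 2-methylcyclopropyl on a saturated chain carbon bound to an oxygen on an aromatic ring. The two share the same atoms, joined differently, the three-membered ring opened into a chain with one double bond outside aromatic rings. Among the measured compounds shown here, no measured pair reports a change of this kind, so no step size is known. The expected step from compound 2 to compound 4 is a 1.4-fold lower number from compound 2 to compound 4 (0.14 log units; within the scatter), a small move toward a lower number, within the scatter. Compound 4 is estimated at 1200 nM, with a range of 400 nM to 3500 nM.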

Compound 4, half-maximal inhibitory concentration: > 2000 nM
Compound 4 gave a limit, no number (the forecaster's own chance of this, stated with the estimate: 5%); middle value at least 1.6-fold (0.22 log units) away from the limit.
By their numbers in this assay, from the lowest: compound 3; then compound 1; then compound 2. At a limit, above all of these: compound 4.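

In this assay, among the compounds shown here, the change from 2-methylcyclopropyl to 2-methylprop-1-en-1-yl, with the same atoms joined differently, gives the only step that can be read: an at least 1.2-fold higher number from compound 2 to compound 4 (0.08 log units; that floor lies within the scatter). Compound 4 gave a limit, not a number, so this change brings no lower number, and the step is only a floor: the limit of > 2000 nM in this assay, at which 1 of the 4 values shown sits. The compounds shown leave open how far the number rises, and whether the lost ring or the new double bond accounts for the step. A saturated 3-methylbutyl chain or an amine on this chain would bear on that.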